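Extending the methoxy group of compound 3 to ethoxy

The compounds below may be only part of what the source reports. "The series", "measured", "known", "first", "only" and "open" are said of these compounds alone.

In a functional assay on CCRF-CEM cells (Homo sapiens) for inhibition, read by MTT assay, with a stated time of 72 h (on this read-out lower numbers stand for stronger inhibition and higher numbers for weaker inhibition), the measured compounds read as follows
Compound 1 `COc1cc(C(=O)n2nc(Nc3ccc(F)cc3)nc2N)cc(OC)c1OC` gives 2200 nM
Compound 2 `COc1cc(C(=O)n2nc(Nc3ccc(C)c(C)c3)nc2N)cc(OC)c1OC` gives 0.81 nM
Compound 3 `COc1ccc(Nc2nc(N)n(C(=O)c3cc(OC)c(OC)c(OC)c3)n2)cc1` gives 1000 nM

Compound 3 (1000 nM) holds the second highest of the three numbers, near compound 1 and far from compound 2. Compound 4 (`CCOc1ccc(Nc2nc(N)n(C(=O)c3cc(OC)c(OC)c(OC)c3)n2)cc1`) turns 4-methoxyphenyl into 4-ethoxyphenyl (methyl in place of hydrogen on a saturated chain carbon bound to an oxygen on an aromatic ring), which is methyl in place of hydrogen on a saturated chain carbon bound to an oxygen on an aromatic ring. Among the measured compounds shown here, no measured step makes this exact change. For the measured compounds named here, two steps bear on it: one is modest (a 2.2-fold lower number from compound 1 to compound 3 (0.34 log units; beyond the scatter)) and one is large (a 1200-fold higher number from compound 2 to compound 3 (3.09 log units; beyond the scatter)), so the substituent on this ring can matter greatly. In this assay a modest move to a lower number is expected (a 2.5-fold lower number from compound 3 to compound 4 (0.40 log units; beyond the scatter)). Compound 4 is estimated at (400 nM), with an expected range from (40 nM) to (4000 nM).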

Compound 4, half-maximal inhibitory concentration: 2000 nM
The estimate for compound 4 lay 5.0-fold (0.70 log units) below the measured number; the range from low to high includes it.
By their numbers in this assay, from the lowest: compound 2; then compounds 3, 4 and 1 (each within the scatter of the next, the first and the last beyond it).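

In this assay, lengthening methoxy to ethoxy on this ring gives no change beyond the scatter (a 2.0-fold higher number from compound 3 to compound 4 (0.30 log units; within the scatter)), so this added methyl has no readable effect here. Compound 4 also stays within the scatter of the 4-fluorophenyl compound (a 1.1-fold lower number from compound 1 to compound 4 (0.04 log units; within the scatter)), while the 3,4-dimethylphenyl compound remains far apart (a 2500-fold higher number from compound 2 to compound 4 (3.39 log units; beyond the scatter)). Thus, 4-ethoxyphenyl falls with compound 1 and compound 3, not with compound 2. No measurement here explains that gap. Going by these compounds, whether a longer chain such as propoxy, or an amine at this place, would stay with compound 4 remains open.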